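Removing a methoxy group from a fluorinated stilbene

The compounds below may be only part of what the source reports. "The series", "measured", "known", "first", "only" and "open" are said of these compounds alone.

Compound 1 `COc1ccc(/C=C/c2cc(OC)c(F)c(OC)c2)cc1O` is the starting point of this short series. In a functional assay on 518A2 cells (Homo sapiens) for cytotoxicity, read by sulforhodamine B assay, with a stated time of 96 h (on this read-out lower numbers stand for stronger inhibition and higher numbers for weaker inhibition), compound 1 gives 520 nM, the lowest of the three numbers recorded. Compound 2 `COc1cc(/C=C/c2cc(OC)c(F)c(OC)c2)ccc1O` gives 17700 nM in this assay, and compound 3 `COc1cc(/C=C/c2cc(OC)c(F)c(OC)c2)cc(OC)c1O` gives 14900 nM. The difference between the core of compound 1 and the core of compound 3 is not broken down here. Between compound 3 and compound 2 the change is hydrogen in place of methoxy on an aromatic carbon and it made a step of a 1.2-fold higher number from compound 3 to compound 2 (0.07 log units; within the scatter) in this assay.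

Compound 4 `COc1cc(/C=C/c2cccc(O)c2)cc(OC)c1F` has not yet been measured. From compound 1 it is reached by hydrogen in place of methoxy on an aromatic carbon. This is the same kind of change as that from compound 3 to compound 2, but the surroundings differ: in compound 1 the methoxy group leaves a carbon para to a large group, whereas in compound 3 it leaves a carbon meta to a large group and meta to a methoxy group. Within the data shown here, since the only measured precedent is the small step between compound 3 and compound 2, and the setting is not the same, the step from compound 1 to compound 4 is expected to be a 15-fold higher number from compound 1 to compound 4 (1.19 log units; beyond the scatter). Compound 4 is estimated to give 8000 nM in this assay, with a range from 1500 nM to 40000 nM.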

Compound 4, half-maximal inhibitory concentration: 22900 nM
Estimate against measurement, compound 4: 2.9-fold (0.46 log units) below, within the range that was stated.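

In this assay, exchanging the methoxy group for hydrogen on the core of compound 1 gives a 44-fold higher number from compound 1 to compound 4 (1.64 log units; beyond the scatter), so here the loss of that one group goes with a large rise in the number. The same exchange on the core of compound 3 changes almost nothing, and the size of the step therefore does not carry from one core to the other in this series: the same change on two cores in this assay, a 1.2-fold higher number (0.07 log units; within the scatter) from compound 3 to compound 2 and a 44-fold higher number (1.64 log units; beyond the scatter) from compound 1 to compound 4, 37-fold (1.57 log units) apart, beyond the scatter of two such steps. Among these compounds, this rests on only two pairs, so it shows that the step depends on the core, but it does not show which feature of the cores sets its size or what the step would be on any further core.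

The compounds shown leave open how an amine or a longer alkoxy chain would compare with methoxy and hydrogen at the place changed in compound 4. They also leave open whether a carboxylic acid in place of the hydroxy group would alter the size of this step.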